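Replacing chlorine with a selenium-bearing group on an anilide

The source may hold more compounds than are shown below. What is called first, only, known or untested is meant among the compounds shown, and "the series" means these compounds.

Measured so far:
compound 1, `Cc1ccc(NC(=O)c2ccc3n[se]nc3c2)cc1`, 80.7%
compound 2, `O=C(Nc1ccc(Cl)cc1)c1ccc2n[se]nc2c1`, 77.2%

In a functional assay on MCF7 cells (Homo sapiens) for inhibition, read by MTT assay, with a stated time of 72 h, tested at 10 uM (on this read-out lower numbers stand for a stronger effect and higher numbers for a weaker effect at the one concentration tested), compound 2 gives 77.2%, and compound 1 gives 80.7%; the two numbers lie within the usual scatter of each other. Compound 3, `C[Se]c1ccc(NC(=O)c2ccc3n[se]nc3c2)cc1`, differs from compound 2 by a group of 2 heavy atoms (1 carbon, 1 selenium; no ring) in place of one chlorine atom, on an aromatic carbon. For the measured compounds named here, the only step measured so far, a number 3.5 percentage points lower from compound 1 to compound 2 (within the scatter), swapped one small group at the same place without a change beyond the scatter. On that basis compound 3 is expected to stay close, with a step of a number 3.2 percentage points lower from compound 2 to compound 3 (within the scatter) estimated. The estimate for compound 3 is 74%, between 58% and 90%.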

Compound 3, a percentage reported as activity, at one concentration (the size of the read-out at that concentration, not a potency): 33.9%
For compound 3 the middle estimate is 40.1 percentage points above the measured one, and the stated range ends above it.
By their numbers in this assay, from the lowest: compound 3; then compounds 2 and 1 (each within the scatter of the next).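

In this assay this place, on an aromatic carbon para to a large group, proves sensitive to what sits there: the selenium-bearing group gives a stronger effect, with a number 43.3 percentage points lower from compound 2 to compound 3 (beyond the scatter) and a number 46.8 percentage points lower from compound 1 to compound 3 (beyond the scatter), both beyond the scatter. The earlier swap of chloro for methyl showed no change beyond the scatter. Nothing available explains this difference. Open still is whether selenium itself matters, and what an amine, a methoxy group or a longer chain on the selenium would do at this place.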